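A few compounds are considered here, and "the series" means these few. Any claim that something is new, unique, unknown or untested is made for them only; others in the source may bear on it.

Measured compounds:
Compound 1, `COc1ccc(-c2nnc(SCC(=O)Nc3ccc(/C(C)=N/O)cc3)n2-c2ccccc2)cc1`, 58%
Compound 2, `CCn1c(SCC(=O)Nc2ccc(C(C)=O)cc2)nnc1-c1ccc(OC)cc1`, 62%
Compound 3, `C=CCn1c(SCC(=O)Nc2ccc(C(C)=O)cc2)nnc1-c1ccc(OC)cc1`, 66%

Compound 3 has the highest of the three numbers in a functional assay on the whole organism (strain albino) for inhibition, with Rattus norvegicus as the target, read by paw edema, with stated times of 30 min and 5 h, at a dose of 0.28 mmol/kg by the oral route (a lower number here means less inhibition, a higher number more inhibition at the dose given (going by the name of the read-out)), but its nearest neighbour compound 2 lies only a number 4 percentage points higher from compound 2 to compound 3 (within the scatter), and compound 1 stands eight points lower, also within the scatter, so no ordering can be claimed among the three.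

The next compound is compound 4, `COc1ccc(-c2nnc(SCC(=O)Nc3ccc(C(C)=O)cc3)n2-c2ccccc2)cc1`. It differs from compound 3 in one place: phenyl in place of allyl on an aromatic nitrogen. Allyl leaves and phenyl enters on an aromatic nitrogen of the five-membered ring.

Going by the values given here, only one measured step changes the group on this nitrogen, the step from compound 2 to compound 3, which altered a saturated chain substituent there by a number 4 percentage points higher from compound 2 to compound 3 (within the scatter), within the scatter. Among the compounds with values here, no measured step exchanges a chain for phenyl at this position with the rest held fixed; compound 1 bears phenyl there but carries an oxime in place of the acetyl, and its value gives no isolated step. The bearing evidence thus shows no movement beyond the scatter, and none is expected from a number 5 percentage points lower from compound 3 to compound 4 (within the scatter).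

Compound 4 is therefore estimated at 61%, with a range from 49% to 73%.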

Compound 4, a percentage reported as inhibition, in the whole organism at one dose (the size of the read-out at that dose, not a potency): 60%
Compound 4: middle estimate off by 1 percentage points, on the high side, and the stated range covers the measured number.
By their numbers in this assay, from the lowest: compounds 1, 4, 2 and 3 (each within the scatter of the next).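

In this assay the aromatic nitrogen of the five-membered ring now carries phenyl with the acetyl held fixed: allyl to phenyl gives a number 6 percentage points lower from compound 3 to compound 4 (within the scatter) and ethyl to phenyl gives a number 2 percentage points lower from compound 2 to compound 4 (within the scatter) so phenyl and the two chains cannot be told apart at this position. The aromatic carbon bearing the acetyl can now also be read with phenyl on the nitrogen, and acetyl in place of the oxime gives a number 2 percentage points higher from compound 1 to compound 4 (within the scatter) so that exchange shows no movement beyond the scatter either. No measurement bears on why these values fall as they do.

From the compounds shown here alone, all four compounds lie within the scatter of one another, so it remains open whether any group at this nitrogen moves the read-out at all. Going by these compounds, how a longer chain or a chain ending in an amine or a carboxylic acid would fare there also stays open.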